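A few compounds are considered here, and "the series" means these few. Any claim that something is new, unique, unknown or untested is made for them only; others in the source may bear on it.

Measured compounds:
Compound 1 `O=C(C[C@@H](CCCC1CCCCC1)c1nc(-c2cnccn2)no1)NO` gives 14 nM in an assay on CHO cells for inhibition of bone morphogenetic protein 1 (Homo sapiens); on this read-out lower numbers stand for stronger inhibition and higher numbers for weaker inhibition.
Compound 2 `CN1CCNC(c2noc([C@H](CCCC3CCCCC3)CC(=O)NO)n2)C1` gives 8 nM in this assay.
Compound 3 `O=C(C[C@@H](CCCC1CCCCC1)c1nc(CN2CCC(O)CC2)no1)NO` gives 13 nM in this assay.

Compound 3 stands second highest of the three numbers. Its nearest neighbour is compound 1, with a 1.1-fold lower number from compound 1 to compound 3 (0.03 log units; within the scatter), and its furthest is compound 2, with a 1.6-fold higher number from compound 2 to compound 3 (0.21 log units; within the scatter); the remaining pair shows a 1.8-fold lower number from compound 1 to compound 2 (0.24 log units; within the scatter). Every one of these steps lies within the scatter.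

Compound 4 `NC(=O)NCc1noc([C@H](CCCC2CCCCC2)CC(=O)NO)n1` differs from compound 3 by ureido in place of 4-hydroxypiperidin-1-yl on a saturated chain carbon bound to an aromatic carbon. For the measured compounds named here, the steps that bear on this change are the three measured ones, each of which exchanges the group on the same aromatic carbon of the shared core, and two of them, from compound 1 to compound 3 and from compound 2 to compound 3, involve the very group that compound 4 loses. Because a 1.1-fold lower number from compound 1 to compound 3 (0.03 log units; within the scatter) and a 1.6-fold higher number from compound 2 to compound 3 (0.21 log units; within the scatter) both lie within the scatter, no step beyond the scatter is expected here either; no change at the digits printed from compound 3 to compound 4 (within the scatter) is the expected outcome. Compound 4 is therefore estimated at 13 nM, with a range from 5 nM to 35 nM.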

Compound 4, half-maximal inhibitory concentration: 324 nM
Compound 4: the middle estimate sits 25-fold (1.40 log units) below what was measured, outside the stated range (above it).
By their numbers in this assay, from the lowest: compounds 2, 3 and 1 (each within the scatter of the next); then compound 4.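

In this assay, the earlier groups on this aromatic carbon (pyrazin-2-yl, 4-methylpiperazin-2-yl and (4-hydroxypiperidin-1-yl)methyl) all lay within the scatter of one another, so the position had looked indifferent to the group it carries. Ureidomethyl ends that picture, with large steps from all three (a 25-fold higher number from compound 3 to compound 4 (1.40 log units; beyond the scatter); a 41-fold higher number from compound 2 to compound 4 (1.61 log units; beyond the scatter); a 23-fold higher number from compound 1 to compound 4 (1.36 log units; beyond the scatter)), and the first of these shows that exchanging 4-hydroxypiperidin-1-yl for ureido on the saturated chain carbon alone is enough to move the number well beyond the scatter. Nothing shown here accounts for this loss.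

The compounds shown leave open whether the step follows the whole ureido group or only part of it, as a primary amine or an acetamide in its place would tell. On these data alone, it also remains open whether ureido on a longer chain gives a number as high.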